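The source may hold more compounds than are shown below. What is called first, only, known or untested is meant among the compounds shown, and "the series" means these compounds.

In a functional assay on MGC-803 cells (Homo sapiens) for antiproliferative activity, read by MTT assay, with a stated time of 48 h (on this read-out higher numbers stand for weaker inhibition and lower numbers for stronger inhibition), compound 1 `COc1ccc(CN(C(=O)CSc2nc3ccccc3s2)c2cc(OC)c(OC)c(OC)c2)cc1` gives 163 nM. Among the compounds with values here, compound 2 `COc1cc(CN(C(=O)CSc2nc3ccccc3s2)c2cc(OC)c(OC)c(OC)c2)cc(OC)c1OC` gives 45700 nM, the highest of the two numbers measured so far, and the only compound near it on this read-out is compound 1, whose number is far lower. Within the data shown here, the single step measured between them, a 280-fold higher number from compound 1 to compound 2 (2.45 log units; beyond the scatter), shows how strongly the group on the saturated chain carbon bound to the amide-type nitrogen can move this number.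

Compound 3 `COc1ccc(CN(C(=O)CSc2nc3ccccc3s2)c2cc(OC)c(OC)c(OC)c2)cc1Br` differs from compound 2 in that place: 3-bromo-4-methoxyphenyl in place of 3,4,5-trimethoxyphenyl on a saturated chain carbon bound to an amide-type nitrogen. This change largely undoes the one seen in that measured step, since the entering group is the 4-methoxyphenyl of compound 1 carrying one extra bromine. A large step downward is therefore expected, though the bromine leaves some uncertainty about how far. Compound 3 is estimated at 300 nM, within 80 nM to 2500 nM, which means an expected step of a 150-fold lower number from compound 2 to compound 3 (2.18 log units; beyond the scatter).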

Compound 3, half-maximal inhibitory concentration: 852 nM
For compound 3 the middle estimate is 2.8-fold (0.45 log units) below the measured one; the measured number falls inside the stated range.
By their numbers in this assay, from the lowest: compound 1; then compound 3; then compound 2.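

Exchanging 3,4,5-trimethoxyphenyl for 3-bromo-4-methoxyphenyl on the saturated chain carbon bound to the amide-type nitrogen gives a 54-fold lower number from compound 2 to compound 3 (1.73 log units; beyond the scatter) in this assay, so most of the strength lost in compound 2 returns with this group. The bromine itself still has a measurable cost, since bromo in place of hydrogen on an aromatic carbon gives a 5.2-fold higher number from compound 1 to compound 3 (0.72 log units; beyond the scatter), a modest step that is beyond the scatter yet much smaller than the step between compound 2 and compound 3. Nothing available explains why these groups differ so much.

Only one replacement for that hydrogen is shown, so it remains open whether chlorine, a hydroxyl or an amine there would match compound 1. A single extra methoxy on the ring of compound 1 would also show how much of the loss in compound 2 one such group can account for.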